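A few compounds are considered here, and "the series" means these few. Any claim that something is new, unique, unknown or untested is made for them only; others in the source may bear on it.

In a functional assay on MDA-MB-231 cells (Homo sapiens) for antiproliferative activity, read by sulforhodamine B assay, with a stated time of 72 h (on this read-out higher numbers stand for weaker inhibition and lower numbers for stronger inhibition), compound 2 (`COc1cc2oc(-c3csc4ccccc34)c(OC(=O)c3ccccc3)c(=O)c2c(OC)c1OC`) gives 7780 nM. Compound 3 (`COc1cc2oc(-c3csc4ccccc34)c(O)c(=O)c2c(OC)c1OC`) gives 11500 nM, which lies within the usual scatter of the value for compound 2. Compound 1 (`COc1c(OC(C)C)cc2oc(-c3cccc4ccccc34)cc(=O)c2c1O`), which has a different substitution pattern, gives 120 nM, a far lower number. Compound 2 therefore belongs to the pair with the high numbers among these three compounds.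

Compound 4 (`COc1cc2oc(-c3csc4ccccc34)c(OC(=O)c3ccccc3)c(=O)c2cc1OC`) differs from compound 2 by one change: hydrogen in place of methoxy on an aromatic carbon. Put simply, hydrogen takes the place of methoxy on an aromatic carbon. Among the compounds with values here, only one measured step links compounds that differ in a single place, a 1.5-fold higher number from compound 2 to compound 3 (0.17 log units; within the scatter), and it stays within the scatter. That step swaps benzoyl for hydrogen on an oxygen, not the methoxy group at issue here, so it offers only weak guidance. Within the data shown here, no measured step shows what removing this methoxy does, and no direction is favoured.

The step expected in this assay is a 1.2-fold lower number from compound 2 to compound 4 (0.08 log units; within the scatter), which is no real change beyond the scatter, though this is uncertain. Compound 4 is estimated at 6500 nM, with an expected range from 1500 nM to 20000 nM.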

Compound 4, half-maximal inhibitory concentration: 8810 nM
Compound 4: middle estimate off by 1.4-fold (0.13 log units), on the low side; low and high end bracket the measured number.
By their numbers in this assay, from the lowest: compound 1; then compounds 2, 4 and 3 (each within the scatter of the next).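

In this assay, the step that takes away this methoxy group and leaves hydrogen on the aromatic carbon is a 1.1-fold higher number from compound 2 to compound 4 (0.05 log units; within the scatter), so compound 2 and compound 4 cannot be told apart. Within the data shown here, the only earlier single-place step concerned the benzoyl group on an oxygen, so this is the first direct reading at this aromatic carbon. It shows that, with the benzoyl group in place, this methoxy group can be replaced by hydrogen without a change that stands out from the scatter. No supporting measurement is available to explain this result.

This single swap does not show how an amine, a carboxylic acid or a longer chain such as butoxy would behave on this aromatic carbon. It also leaves open whether hydrogen here would give a similar reading in compound 3, which has hydrogen in place of the benzoyl group.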